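4-Fluorobenzyl in Place of 4-Methylbenzyl

The source may hold more compounds than are shown below. What is called first, only, known or untested is meant among the compounds shown, and "the series" means these compounds.

In a functional assay on Cortical neurone cells (Mus musculus, strain C57BL/6), read by FLIPR and calcium flux, with a stated time of 8 min (on this read-out higher numbers stand for weaker inhibition and lower numbers for stronger inhibition), compound 1 (`O=c1cc(Cc2ccc(Cl)cc2)[nH]c2nc(Cc3ccc(F)cc3)nn12`) gives 3650 nM and compound 2 (`Cc1ccc(Cc2nc3[nH]c(-c4ccccc4)cc(=O)n3n2)cc1`) gives 1150 nM as the lower of the two numbers, a gap beyond the scatter. Compound 3 (`O=c1cc(-c2ccccc2)[nH]c2nc(Cc3ccc(F)cc3)nn12`) has not yet been measured and carries fluoro in place of methyl on an aromatic carbon para to a large group. For the measured compounds named here, no measured pair shows this kind of step, so no change beyond the scatter is expected in this assay in either direction. The expected step of a 1.1-fold higher number from compound 2 to compound 3 (0.05 log units; within the scatter) is small. Compound 3 is estimated at 1300 nM with 500 nM to 3500 nM as its range.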

Compound 3, half-maximal inhibitory concentration: 2520 nM
Compound 3: the middle estimate sits 1.9-fold (0.29 log units) below what was measured, and the stated range covers the measured number.
By their numbers in this assay, from the lowest: compound 2; then compounds 3 and 1 (each within the scatter of the next).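

In this assay, this first measured step at the position shows that fluoro does not simply stand in for methyl on this aromatic carbon: the number rises beyond the scatter (a 2.2-fold higher number from compound 2 to compound 3 (0.34 log units; beyond the scatter)). Phenyl in place of 4-chlorobenzyl, a change elsewhere on the core, stays within the scatter (a 1.4-fold lower number from compound 1 to compound 3 (0.16 log units; within the scatter)). Nothing measured here explains the step from methyl to fluoro. Going by these compounds, whether a methoxy group or an amine in place of the fluoro would hold or lower the number remains open.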